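Swapping Pyridin-3-yl for Pyridin-4-yl Across Two Cores

A few compounds are considered here, and "the series" means these few. Any claim that something is new, unique, unknown or untested is made for them only; others in the source may bear on it.

Compound 1 `CN1C/C(=C\c2cccnc2)C(=O)/C(=C/c2ccccc2F)C1` and compound 2 `CN1C/C(=C\c2ccncc2)C(=O)/C(=C/c2ccccc2F)C1` share one core, while compound 3 `O=C1/C(=C/c2cccnc2)CNC/C1=C\c1ccccc1C(F)(F)F` and compound 4 `O=C1/C(=C/c2ccncc2)CNC/C1=C\c1ccccc1C(F)(F)F` share another; the difference between the two cores is not broken down here. In a functional assay on HepG2 cells (Homo sapiens) for cytotoxicity, read by MTT assay, with a stated time of 24 h (a lower number here means a stronger inhibitor, a higher number a weaker inhibitor), compound 1 gives 4810 nM and compound 2 gives 4600 nM, so that the step of a 1.0-fold lower number from compound 1 to compound 2 (0.02 log units; within the scatter) went with pyridin-4-yl in place of pyridin-3-yl on a double-bonded chain carbon bound to a double-bonded ring carbon. In this assay compound 3 gives 5020 nM. Compound 4 carries the same change on its own core, namely (pyridin-4-yl in place of pyridin-3-yl on a double-bonded chain carbon bound to a double-bonded ring carbon). Because the step of a 1.0-fold lower number from compound 1 to compound 2 (0.02 log units; within the scatter) stayed within the scatter, the step from compound 3 to compound 4 is expected to be about as small, a 1.1-fold lower number from compound 3 to compound 4 (0.03 log units; within the scatter). Compound 4 is accordingly estimated at 4700 nM in this assay, with a likely range from 2800 nM to 8000 nM.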

Compound 4, half-maximal inhibitory concentration: 6130 nM
For compound 4 the middle estimate is 1.3-fold (0.12 log units) below the measured one; the measured number falls inside the stated range.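

In this assay the change from pyridin-3-yl to pyridin-4-yl gave a 1.2-fold higher number from compound 3 to compound 4 (0.09 log units; within the scatter) and so stayed as small on this core as on the first. The two steps do not differ from each other: the same change on two cores in this assay, a 1.0-fold lower number (0.02 log units; within the scatter) from compound 1 to compound 2 and a 1.2-fold higher number (0.09 log units; within the scatter) from compound 3 to compound 4, 1.3-fold (0.11 log units) apart, within the scatter of two such steps. This shows that the change carried from one core to the other without a step that could be read in this cell assay, but it rests on two pairs of compounds, gives no direction for the change, and says nothing about other cores or other assays.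

The compounds shown leave open whether a phenyl or a pyridin-2-yl group in the same place would shift the number beyond the scatter.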